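The compounds below may be only part of what the source reports. "The series", "measured", "known", "first", "only" and "open" are said of these compounds alone.

Among the measured compounds shown here, compound 3 `CC(C)(C)c1cc(/C=C/C(=O)NCCC2CCN(Cc3ccc(F)c(F)c3)CC2)cc(C(C)(C)C)c1O` stands at the top of the numbers so far: in an assay on isolated protein for inhibition of Amine oxidase [flavin-containing] A (Homo sapiens), read by fluorescence, with stated times of 15 min and 20 min (on this read-out higher numbers stand for weaker inhibition and lower numbers for stronger inhibition), compound 3 gives 64500 nM, while compound 1 `CC(C)(C)c1cc(/C=C/C(=O)NCCC2CCN(Cc3ccccc3F)CC2)cc(C(C)(C)C)c1O` gives 60200 nM and compound 2 `CC(C)(C)c1cc(/C=C/C(=O)NCCC2CCN(Cc3ccc(F)cc3)CC2)cc(C(C)(C)C)c1O` gives 59600 nM, and its distance to either of them is within the scatter. Compound 4 `CC(C)(C)c1cc(/C=C/C(=O)NCCC2CCN(Cc3ccccc3Cl)CC2)cc(C(C)(C)C)c1O` carries the change (2-chlorophenyl in place of 3,4-difluorophenyl on a saturated chain carbon bound to an amine nitrogen in a ring), so the aryl group on the saturated chain carbon bound to the ring amine nitrogen changes once more. Earlier moves of the same kind left the read-out unchanged: the step from 2-fluorophenyl to 3,4-difluorophenyl ran a 1.1-fold higher number from compound 1 to compound 3 (0.03 log units; within the scatter), the move from 2-fluorophenyl to 4-fluorophenyl ran a 1.0-fold lower number from compound 1 to compound 2 (0.00 log units; within the scatter), and adding a fluoro to an aromatic carbon ran a 1.1-fold higher number from compound 2 to compound 3 (0.03 log units; within the scatter). For the measured compounds named here, no measured compound holds a 2-chlorophenyl, so nothing speaks directly for chlorine, but every change at this place so far has stayed within the scatter. Compound 4 is therefore expected to show no step beyond the scatter, estimated at a 1.0-fold lower number from compound 3 to compound 4 (0.02 log units; within the scatter). The estimate for compound 4 in this assay is 62000 nM, with a range from 30000 nM to 125000 nM.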

Compound 4, half-maximal inhibitory concentration: 72100 nM
Estimate against measurement, compound 4: 1.2-fold (0.07 log units) below; the range from low to high includes it.
By their numbers in this assay, from the lowest: compounds 2, 1, 3 and 4 (each within the scatter of the next).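

In this assay, chlorine at this place on a saturated chain carbon bound to an amine nitrogen in a ring gives no step beyond the scatter: chloro in place of fluoro on an aromatic carbon gives (a 1.2-fold higher number from compound 1 to compound 4 (0.08 log units; within the scatter)), while 2-chlorophenyl gives (a 1.1-fold higher number from compound 3 to compound 4 (0.05 log units; within the scatter)) in place of 3,4-difluorophenyl and (a 1.2-fold higher number from compound 2 to compound 4 (0.08 log units; within the scatter)) in place of 4-fluorophenyl. The flat picture seen with fluorine alone therefore extends to a second halogen, and all four aryl groups stand within the scatter of one another. No measurement offered here accounts for this lack of response.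

As far as these compounds go, all four compounds carry halogen on this aryl ring, so it stays open whether a plain phenyl, a methoxyphenyl or a carboxylic acid on that ring would step beyond the scatter. Also open, from the compounds shown here alone, is whether a change elsewhere on the shared core, such as a longer chain before the amide, would move the number at all.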